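From hydroxycarbamoyl to 2-(hydroxycarbamoyl)ethenyl on compound 1

The source may hold more compounds than are shown below. What is called first, only, known or untested is meant among the compounds shown, and "the series" means these compounds.

In a functional assay on HCT-116 cells (Homo sapiens) for inhibition, read by MTT assay, with a stated time of 48 h (a higher number here means a weaker inhibitor, a lower number a stronger inhibitor), compound 1 `O=C(NO)c1ccc(Oc2no[n+]([O-])c2S(=O)(=O)c2ccccc2)cc1` gives 2700 nM and compound 2 `COc1cc(C(=O)NO)ccc1Oc1no[n+]([O-])c1S(=O)(=O)c1ccccc1` gives 5030 nM. Going by the values given here, these are the only two numbers so far, and they lie within the scatter of each other, so compound 1 holds no clear rank. Compound 3 `O=C(/C=C/c1ccc(Oc2no[n+]([O-])c2S(=O)(=O)c2ccccc2)cc1)NO` carries 2-(hydroxycarbamoyl)ethenyl in place of hydroxycarbamoyl on an aromatic carbon, para to a large group: 2-(hydroxycarbamoyl)ethenyl in place of hydroxycarbamoyl on an aromatic carbon. Among the compounds with values here, the only measured step is a 1.9-fold higher number from compound 1 to compound 2 (0.27 log units; within the scatter), for methoxy in place of hydrogen on an aromatic carbon, which is a different change and sets no size for this one. Within the data shown here, no measured compound carries the entering group, so a modest move towards a lower number in this assay is only a tentative expectation. The expected step is a 2.1-fold lower number from compound 1 to compound 3 (0.32 log units; beyond the scatter). Compound 3 is estimated at 1300 nM, with an expected range of 400 nM to 4000 nM.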

Compound 3, half-maximal inhibitory concentration: 8090 nM
For compound 3 the middle estimate is 6.2-fold (0.79 log units) below the measured one; the whole stated range lies below it.
By their numbers in this assay, from the lowest: compounds 1, 2 and 3 (each within the scatter of the next, the first and the last beyond it).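

Swapping hydroxycarbamoyl for 2-(hydroxycarbamoyl)ethenyl on the aromatic carbon gives, in this assay, a 3.0-fold higher number from compound 1 to compound 3 (0.48 log units; beyond the scatter), the first single-place step in the series that lies beyond the scatter. The earlier step, a 1.9-fold higher number from compound 1 to compound 2 (0.27 log units; within the scatter), could not show a clear response to any change, whereas this position does respond, and the move is towards a weaker inhibitor. Going by these compounds alone, this rests on one pair, so it describes only this change on the core of compound 1 and sets no trend for other groups at this position.

The compounds shown do not separate the added chain length from the added double bond, which a saturated 2-(hydroxycarbamoyl)ethyl group or a carboxylic acid in place of the hydroxycarbamoyl end could begin to address. Nothing available accounts for the size or direction of this step.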